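Amide series: carboxy for ethyl on the amine chain

This account rests on a few compounds, and the source may have more. Where it says the series, first, only, none or still open, it means among the compounds named here.

Measured so far in a functional assay on MCF7 cells (Homo sapiens) for antiproliferative activity; a higher number here means a weaker inhibitor, a lower number a stronger inhibitor:
compound 1, `CC(=O)Oc1ccc(C(=O)Nc2cc3ccc(OCC4CCCNC4)c(C)c3oc2=O)cc1CC=C(C)C`: 820 nM
compound 2, `CCCNCCCOc1ccc2cc(NC(=O)c3ccc(O)c(CC=C(C)C)c3)c(=O)oc2c1C`: 980 nM

Two compounds of the series carry a number in this assay. Compound 2 gives 980 nM, and compound 1 gives 820 nM; the gap between these two numbers lies within the scatter, so compound 2 stands level with compound 1 and neither can be called the stronger or weaker inhibitor on these data.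

Compound 3, `CC(C)=CCc1cc(C(=O)Nc2cc3ccc(OCCCNCC(=O)O)c(C)c3oc2=O)ccc1O`, has not yet been measured. It differs from compound 2 in one place: carboxy in place of ethyl on a saturated chain carbon bound to an amine nitrogen. Among the compounds with values here, no pair of measured compounds differs by a change of this kind, so nothing measured here fixes the size of the step; it has to be expected rather than read off.

In this assay the step is expected to be a 2.6-fold higher number from compound 2 to compound 3 (0.41 log units; beyond the scatter), a move toward weaker inhibition that goes beyond the scatter. Compound 3 is estimated at 2500 nM, with a range from 800 nM to 8000 nM.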

Compound 3, half-maximal inhibitory concentration: 18100 nM
Compound 3: the middle estimate sits 7.2-fold (0.86 log units) below what was measured; measured number above the stated range.
By their numbers in this assay, from the lowest: compounds 1 and 2 (each within the scatter of the next); then compound 3.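

In this assay, within the data shown here, the amine chain of compound 2 proves sensitive at its far end: carboxy in place of ethyl on a saturated chain carbon bound to an amine nitrogen gives an 18-fold higher number from compound 2 to compound 3 (1.27 log units; beyond the scatter) and is the first step that can be read. The earlier pair could not show this, since compound 1 and compound 2 differ in more than one place and their numbers say nothing about a single change on this chain. So this position does not accept every replacement, and a large move in the number can come from this one change; no measurement at hand bears on the reason for the size of the step.

The compounds shown leave open whether a methyl ester or a primary amide on the same chain carbon would stand close to compound 2 or close to compound 3. They also leave open whether a hydroxymethyl group there, or a longer chain ending in the carboxylic acid, would give a step of similar size.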